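The source may report more compounds than this note shows. Statements on the series, on what has been measured and on what is new or still open speak of the compounds shown alone.

Three compounds share one core and differ only in the group on an aromatic carbon: compound 1 `OC1CCN(c2nccnc2OC2CN(c3ccc4ccccc4n3)C2)CC1`, compound 2 `OC1CN(c2nccnc2OC2CN(c3ccc4ccccc4n3)C2)C1` and compound 3 `c1ccc2nc(N3CC(Oc4nccnc4-c4cncnc4)C3)ccc2c1`. In a physicochemical assay for solubility, in phosphate buffer, at pH 7.4 (on this read-out higher numbers stand for higher solubility and lower numbers for lower solubility), compound 3 gives 254000 nM, the highest of the three numbers, while compound 1 gives 99000 nM and compound 2 gives 41000 nM.

The next step leads to compound 4 `c1ccc2nc(N3CC(Oc4nccnc4-c4cccc5ncccc45)C3)ccc2c1`, in which quinolin-5-yl takes the place of pyrimidin-5-yl: quinolin-5-yl in place of pyrimidin-5-yl on an aromatic carbon. Three measured steps at this same place bear on the change: a 2.4-fold lower number from compound 1 to compound 2 (0.38 log units; beyond the scatter), a 2.6-fold higher number from compound 1 to compound 3 (0.41 log units; beyond the scatter) and a 6.2-fold higher number from compound 2 to compound 3 (0.79 log units; beyond the scatter). Among the measured compounds shown here, all are modest, but none involves an aromatic ring of carbon only at this place, so they offer a scale for the step and no direct precedent.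

Since compound 3 stands at the top of the series with 254000 nM, and the entering group is the larger of the two, a lower number is expected in this assay, probably by more than the largest measured step. The expected change is a 13-fold lower number from compound 3 to compound 4 (1.10 log units; beyond the scatter). Compound 4 is estimated at 20000 nM, with an expected range from 3000 nM to 90000 nM.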

Compound 4, solubility: 47000 nM
Compound 4: the middle estimate sits 2.4-fold (0.37 log units) below what was measured, and the stated range covers the measured number.
By their numbers in this assay, from the lowest: compounds 2 and 4 (each within the scatter of the next); then compound 1; then compound 3.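

With quinolin-5-yl, the place on an aromatic carbon next to the ring nitrogen now carries a second aromatic group, and in this assay the two aromatic groups do not read alike: a 5.4-fold lower number from compound 3 to compound 4 (0.73 log units; beyond the scatter). An aromatic group at this place therefore does not by itself give a number at the level of compound 3, and compound 4 falls in with the compounds bearing the hydroxylated rings: it cannot be told apart from the 3-hydroxyazetidin-1-yl compound, a 1.1-fold higher number from compound 2 to compound 4 (0.06 log units; within the scatter), and it still lies under the 4-hydroxypiperidin-1-yl compound, a 2.1-fold lower number from compound 1 to compound 4 (0.32 log units; beyond the scatter). No measurement offered here explains why the two aromatic groups differ.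

Quinolin-5-yl differs from pyrimidin-5-yl in its size, in its number of rings and in its ring nitrogens all at once, so these compounds cannot show which of those differences goes with the step. From the compounds shown here alone, it remains open where a single phenyl ring or pyridin-3-yl ring would stand at this place, and whether an open-chain amine or a carboxylic acid there would reach or pass the number of compound 3.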